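Swapping Bromo for Chloro on a Dichalcone Scaffold

The source may report more compounds than this note shows. Statements on the series, on what has been measured and on what is new or still open speak of the compounds shown alone.

This account concerns three measured chalcone-type compounds and one that awaits testing. In a functional assay on MDA-MB-231 cells (Homo sapiens) for cytotoxicity, read by MTT assay, with a stated time of 24 h (a lower number here means a stronger inhibitor, a higher number a weaker inhibitor), compound 1 `Cc1cc(O)c(C(=O)/C=C/c2cccc3ccccc23)c(-c2ccc(Cl)cc2)c1C(=O)/C=C/c1cccc2ccccc12` gives 30000 nM, compound 2 `Cc1cc(O)c(C(=O)/C=C/c2ccccc2)c(-c2ccc(Br)cc2)c1C(=O)/C=C/c1ccccc1` gives 8000 nM, and compound 3 `Cc1cc(O)c(C(=O)/C=C/c2ccc(F)cc2)c(-c2ccc(OCc3ccccc3)cc2)c1C(=O)/C=C/c1ccc(F)cc1` gives 15000 nM. Compound 2 has the lowest number of the three; its gap to compound 3 lies within the scatter, while its gap to compound 1 lies beyond it. Compound 4 `Cc1cc(O)c(C(=O)/C=C/c2ccccc2)c(-c2ccc(Cl)cc2)c1C(=O)/C=C/c1ccccc1` differs from compound 2 only in this: chloro in place of bromo on an aromatic carbon. Among the compounds with values here, no measured pair shows this exchange alone, so no step is known for it. Little is expected of it in this assay, no shift beyond the scatter in either direction, so the estimated step of a 1.3-fold higher number from compound 2 to compound 4 (0.10 log units; within the scatter) is small. Compound 4 is therefore estimated at 10000 nM, within 4000 nM to 25000 nM.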

Compound 4, half-maximal inhibitory concentration: 4400 nM
The estimate for compound 4 lay 2.3-fold (0.36 log units) above the measured number; the range from low to high includes it.
By their numbers in this assay, from the lowest: compounds 4, 2, 3 and 1 (each within the scatter of the next, the first and the last beyond it).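

The earlier compounds shown here each differed in more than one place, so they could not isolate this exchange. Compound 4 now does so, giving a 1.8-fold lower number from compound 2 to compound 4 (0.26 log units; within the scatter) in this assay, which shows that 4-bromophenyl and 4-chlorophenyl cannot be told apart in this position, para to a large group. Nothing at hand gives a reason for this reading. Still open, going by these compounds, is whether an amine, a hydroxyl or a carboxylic acid in the same place would read differently, and whether this exchange would give a similar step on a compound with different side arms.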